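This account rests on a few compounds, and the source may have more. Where it says the series, first, only, none or still open, it means among the compounds named here.

Measured so far:
compound 1 `CCCN1C/C(=C\c2ccc(OC)c(OC)c2)C(=O)/C(=C/c2ccc(OC)c(OC)c2)C1`: 16000 nM
compound 2 `CCC(=O)N1C/C(=C\c2cc(OC)c(OC)c(OC)c2)C(=O)/C(=C/c2cc(OC)c(OC)c(OC)c2)C1`: 4400 nM

In a functional assay on NCI-H1650 cells (Homo sapiens) for cytotoxicity, read by MTT assay, with a stated time of 72 h (a lower number here means a stronger inhibitor, a higher number a weaker inhibitor), compound 2 gives 4400 nM, the lowest of the two numbers recorded. Compound 1 gives 16000 nM, a gap from compound 2 that lies beyond the usual scatter. Compound 1 and compound 2 differ in more than one place, so no single change can be held to account for the gap.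

Compound 3 `COc1cc(/C=C2\CN(C(=O)C(C)C)C/C(=C\c3cc(OC)c(OC)c(OC)c3)C2=O)cc(OC)c1OC` has not been measured in this assay. It differs from compound 2 in one place: methyl in place of hydrogen on a saturated chain carbon bound to a carbonyl carbon and a saturated chain carbon. Cut one bond further out, the change reads propanoyl to isopropylcarbonyl. Going by the values given here, no measured pair shows this change, so the data give no direction for it; a small change of this kind is expected to leave the number close to that of compound 2. The expected step, a 1.1-fold lower number from compound 2 to compound 3 (0.04 log units; within the scatter), stays within the scatter. Compound 3 is estimated at 4000 nM, with a range from 1500 nM to 12000 nM.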

Compound 3, half-maximal inhibitory concentration: 10800 nM
Compound 3: the middle estimate sits 2.7-fold (0.43 log units) below what was measured, and the stated range covers the measured number.
By their numbers in this assay, from the lowest: compound 2; then compounds 3 and 1 (each within the scatter of the next).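

In this assay, methyl in place of hydrogen on a saturated chain carbon bound to a carbonyl carbon and a saturated chain carbon gives a 2.5-fold higher number from compound 2 to compound 3 (0.39 log units; beyond the scatter), a modest step towards weaker inhibition. Going by these compounds alone, this is the first comparison that isolates a single place, since compound 1 and compound 2 differ in more than one; it shows that the number responds to the change from propanoyl to isopropylcarbonyl, and in which direction. Nothing available accounts for the step.

This single pair does not show whether the step comes with the added carbon as such or with the isopropyl shape. Going by these compounds, a butanoyl or acetyl group in place of propanoyl would bear on that, and whether the same change holds on the core of compound 1 remains open.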